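The compounds below may be only part of what the source reports. "The series", "measured", "known", "first", "only" and "open" are said of these compounds alone.

Compound 1 `O=C(/C=C/c1cccnc1)NCCCCCc1ccc(S(=O)(=O)Nc2ccccc2)cc1`: 333 nM
Compound 2 `Cc1ccc(NS(=O)(=O)c2cccc(CCCCCCNC(=O)/C=C/c3cccnc3)c2)cc1`: 38.8 nM

In a functional assay on HeLa cells (Homo sapiens) for inhibition, read by CCK-8 assay, with a stated time of 72 h (on this read-out higher numbers stand for weaker inhibition and lower numbers for stronger inhibition), compound 2 gives 38.8 nM and holds the lower number of the two measured compounds. Compound 1 gives 333 nM on the same read-out, a gap beyond the scatter. Compound 3 `CC(C)(C)c1ccc(NS(=O)(=O)c2cccc(CCCCCCNC(=O)/C=C/c3cccnc3)c2)cc1` differs from compound 2 in one place, and tert-butyl in place of methyl on an aromatic carbon counts the change: tert-butyl in place of methyl on an aromatic carbon, para to a large group. Among the measured compounds shown here, no measured pair isolates a change of this kind, so the expectation rests on compound 2 and the change alone, and it is a loose one. The expected move a 1.3-fold higher number from compound 2 to compound 3 (0.11 log units; within the scatter) is small and towards a higher number, meaning slightly weaker inhibition, and it is expected to stay within the scatter. In this assay the estimate for compound 3 is 50 nM with an expected range from 15 nM to 170 nM on this read-out.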

Compound 3, half-maximal inhibitory concentration: 1520 nM
Estimate against measurement, compound 3: 30-fold (1.48 log units) below, and the stated range ends below it.
By their numbers in this assay, from the lowest: compound 2; then compound 1; then compound 3.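

In this assay, tert-butyl in place of methyl gives a 39-fold higher number from compound 2 to compound 3 (1.59 log units; beyond the scatter), so inhibition in these cells is sensitive to what this aromatic carbon, para to a large group, carries. Both groups contain only carbon, with no ring, no hydrogen-bond donor or acceptor and no net charge, yet the change still weakens inhibition well beyond the scatter. No measurement shown here explains the loss, and its cause remains unassigned.

The compounds shown leave open whether inhibition falls gradually or abruptly between methyl and tert-butyl, which ethyl or isopropyl at the same carbon could help to settle. They also leave open how a methoxy group, a chlorine atom or a trifluoromethyl group would behave there, and whether any group at this carbon can match methyl.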